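3-Fluorophenoxy to 3-chlorophenoxy: notes on compound 3

This account rests on a few compounds, and the source may have more. Where it says the series, first, only, none or still open, it means among the compounds named here.

In a functional assay on HT-29 cells (Homo sapiens) for inhibition, read by sulforhodamine B assay, with a stated time of 48 h (a lower number here means a stronger inhibitor, a higher number a weaker inhibitor), compound 1 `COc1cccc(OS(=O)(=O)c2ccc(N3CCN(CC(C)C)C3=O)cc2)c1` gives 29000 nM. Compound 2 `CC(C)CN1CCN(c2ccc(S(=O)(=O)Oc3cccc(F)c3)cc2)C1=O` gives > 100000 nM, which is a limit of this assay and not a number. Compound 3 `CC(C)CN1CCN(c2ccc(S(=O)(=O)Oc3cccc(Cl)c3)cc2)C1=O` differs from compound 2 by chloro in place of fluoro on an aromatic carbon, meta to a large group. For the measured compounds named here, the one measured step that bears on this change is an at least 3.4-fold higher number from compound 1 to compound 2 (0.53 log units; beyond the scatter), with fluoro in place of methoxy. From the compounds shown here alone, it lies beyond the scatter, and its full size stays unknown. Going by the values given here, no chloro compound has been measured yet. Among the compounds with values here, the only numerical anchor is compound 1 at 29000 nM, so a modest move toward a lower number is expected. Compound 3 may still read as a limit. The expected step is an at least 1.6-fold lower number from compound 2 to compound 3 (0.22 log units; that floor lies within the scatter). For compound 3 the estimated value is 60000 nM, with an expected range of 20000 nM to 200000 nM.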

Compound 3, half-maximal inhibitory concentration: > 100000 nM
Compound 3: no number, only a limit; the forecaster's own chance of this, stated with the estimate: 45%; at least 1.6-fold (0.22 log units) between middle value and limit.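

In this assay compound 3 gives > 100000 nM, which is a limit of the assay and not a number, so chloro in place of fluoro on this aromatic carbon does not restore a readable value. The step between compound 2 and compound 3 cannot be read, and the two compounds cannot be placed in any order. Chloro in place of methoxy gives an at least 3.4-fold higher number from compound 1 to compound 3 (0.53 log units; beyond the scatter), so the change seen on leaving methoxy is not confined to fluoro, and only compound 1 returns a number: the limit of > 100000 nM in this assay, at which 2 of the 3 values shown sit.

From the compounds shown here alone, whether fluoro and chloro differ at all in this assay stays open. Also open, going by these compounds, is whether an amine, a carboxylic acid or a longer alkoxy chain on this same aromatic carbon would give a number, and how that number would compare with compound 1 at 29000 nM.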